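A few compounds are considered here, and "the series" means these few. Any claim that something is new, unique, unknown or untested is made for them only; others in the source may bear on it.

In a functional assay on U-87MG ATCC cells for antiproliferative activity against U-87 MG (Homo sapiens), read by spectrophotometry, with a stated time of 2 days (on this read-out higher numbers stand for weaker inhibition of growth and lower numbers for stronger inhibition of growth), compound 1 (`COc1ccc(Nc2ncc(C(F)(F)F)c(N3Cc4cccc(N(C)S(C)(=O)=O)c4C3)n2)cc1C(F)(F)F`) gives 29400 nM. Compound 2 (`COc1cc(Nc2ncc(C(F)(F)F)c(N3Cc4cccc(N(C)S(C)(=O)=O)c4C3)n2)cc(OC)c1`) reads > 30000 nM, which is a limit of the assay. Compound 3 (`Cc1ccc(Nc2ncc(C(F)(F)F)c(N3Cc4cccc(N(C)S(C)(=O)=O)c4C3)n2)c(C)c1`) reads > 30000 nM, also a limit, so it stands at the limit of > 30000 nM in this assay, at which 2 of the 3 values shown sit.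

Compound 4 (`CN(c1cccc2c1CN(c1nc(Nc3cc(Cl)cc(C(F)(F)F)c3)ncc1C(F)(F)F)C2)S(C)(=O)=O`) differs from compound 3 in one group: 3-chloro-5-(trifluoromethyl)phenyl in place of 2,4-dimethylphenyl on a nitrogen on an aromatic ring. The steps bearing on this are an at least 1.0-fold higher number from compound 1 to compound 3 (0.00 log units; that floor lies within the scatter) and an at least 1.0-fold higher number from compound 1 to compound 2 (0.00 log units; that floor lies within the scatter). Also measured is a step that the two limits leave unreadable from compound 2 to compound 3. The entering group carries a trifluoromethyl, as does compound 1 at 29400 nM, so only a small move towards lower numbers is expected in this assay, possibly none beyond the scatter. For compound 4 the estimated value is 24000 nM, with an expected range of 9000 nM to 45000 nM. The estimate means an at least 1.2-fold lower number from compound 3 to compound 4 (0.09 log units; that floor lies within the scatter).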

Compound 4, concentration for 50% growth inhibition: 5500 nM
Estimate against measurement, compound 4: 4.4-fold (0.64 log units) above; measured number below the stated range.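

In this assay, the group on this nitrogen moves the read-out clear of the scatter: 3-chloro-5-(trifluoromethyl)phenyl gives an at least 5.4-fold lower number from compound 3 to compound 4 (0.73 log units; beyond the scatter) and an at least 5.4-fold lower number from compound 2 to compound 4 (0.73 log units; beyond the scatter). A trifluoromethyl is present on both sides of a 5.3-fold lower number from compound 1 to compound 4 (0.73 log units; beyond the scatter), so that group alone does not set the value. Compound 2 and compound 3 remain limits: the limit of > 30000 nM in this assay, at which 2 of the 4 values shown sit.

As far as these compounds go, the share of the chlorine in these steps stays open. So does the outcome with an amine or a carboxylic acid on this phenyl ring.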